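The source may hold more compounds than are shown below. What is called first, only, known or untested is meant among the compounds shown, and "the series" means these compounds.

Of the compounds shown here, three have so far been measured in an ADME assay on cells (Splenocyte, Mus musculus, strain BALB/c) for cytotoxicity, read by MTT assay, tested at 10 ug/mL; on this read-out lower numbers stand for a weaker effect and higher numbers for a stronger effect at the one concentration tested. Compound 1 `CCCCCCCCCCCCCCC(CO)N(CCCC)CCCC` gives 11.7%, compound 2 `CCCCCCCCCCCCCCC(C(=O)O)N(CC)CC` gives 12.1%, and compound 3 `CCCCCCCCCCCCCCC(NCCCC)C(=O)O` gives 5.1%. Compound 3 holds the lowest of the three numbers, yet all three lie within the scatter of one another, so no order among them can be read from these data. For the measured compounds named here, the single step between measured compounds is a number 7 percentage points lower from compound 2 to compound 3 (within the scatter), which exchanged the substituents on the amine nitrogen. Compound 4 `CCCCCCCCCCCCCCC(C(=O)O)N(CCCC)CCCC` has not yet been measured; it differs from compound 3 by butyl in place of hydrogen on an amine nitrogen. Going by the values given here, the only step that bears on this change is the one from compound 2 to compound 3, which likewise reworked the substitution on the amine nitrogen and stayed within the scatter. Compound 1, which also carries a dibutylamino group, gave a number close to that of compound 3. On this basis compound 4 is expected to show a number 4.9 percentage points higher from compound 3 to compound 4 (within the scatter), a change not beyond the scatter. The estimated value for compound 4 is 10%, with a range from 2% to 20%.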

Compound 4, a percentage reported as activity, at one concentration (the size of the read-out at that concentration, not a potency): 12.5%
Compound 4: the middle estimate sits 2.5 percentage points below what was measured, and the stated range covers the measured number.
By their numbers in this assay, from the lowest: compounds 3, 1, 2 and 4 (each within the scatter of the next).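

In this assay, butyl in place of hydrogen on the amine nitrogen gave a number 7.4 percentage points higher from compound 3 to compound 4 (within the scatter), so the change from butylamino to dibutylamino at this position shows no difference that can be read. The two further exchanges agree with this: dibutylamino in place of diethylamino gave a number 0.4 percentage points higher from compound 2 to compound 4 (within the scatter), and carboxy in place of hydroxymethyl gave a number 0.8 percentage points higher from compound 1 to compound 4 (within the scatter), so neither exchange separates its pair of compounds. No supporting information is available to explain these readings. The compounds shown leave open whether a cyclic amine such as piperidine, or an unsubstituted amine, on this carbon would give a number beyond the scatter. As far as these compounds go, it also remains open whether an amide or ester in place of the carboxylic acid, or a shorter chain, would do so.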